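Aryl exchange on the shared core: compound 4 expectation

The source may report more compounds than this note shows. Statements on the series, on what has been measured and on what is new or still open speak of the compounds shown alone.

Compound 1 `Oc1cc(C(F)(F)F)ccc1-c1nc(-c2ccccc2O)n(-c2ccc(Br)cc2)n1` in a functional assay on PC-12 cells (Rattus norvegicus) for cytotoxicity, read by MTT assay, with stated times of 2 h and 24 h, tested at 10 uM (a higher number here means a stronger effect of the compound at the concentration tested, a lower number a weaker effect), gives 100%. Compound 2 `Oc1cc(C(F)(F)F)ccc1-c1nc(-c2ccccc2O)n(-c2ccc(C(F)(F)F)cc2)n1` gives 102% and compound 3 `Oc1cc(C(F)(F)F)ccc1-c1nc(-c2ccccc2O)n(-c2ccc(OC(F)(F)F)cc2)n1` gives 92.5%. The three steps among them all stay within scatter: a number 2 percentage points higher from compound 1 to compound 2 (within the scatter), a number 7.5 percentage points lower from compound 1 to compound 3 (within the scatter), a number 9.5 percentage points lower from compound 2 to compound 3 (within the scatter). Within the data shown here, of the three numbers the one for compound 3 is the lowest, but its gaps to compound 1 and compound 2 are both within scatter, so no order can be read from them. Compound 4 `Oc1cc(C(F)(F)F)ccc1-c1nc(-c2ccccc2O)n(-c2ccc(Cl)cc2Cl)n1` differs from compound 3 by 2,4-dichlorophenyl in place of 4-(trifluoromethoxy)phenyl on an aromatic nitrogen. Among the measured compounds shown here, no measured step exchanges the whole aryl group on that aromatic nitrogen; the three measured swaps of a single substituent on it each stayed within scatter, which is the only guide here. The expected step is a number 4.5 percentage points higher from compound 3 to compound 4 (within the scatter). Compound 4 is therefore estimated at 97%, with a range from 85% to 108%.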

Compound 4, a percentage reported as activity, at one concentration (the size of the read-out at that concentration, not a potency): 95.2%
Estimate against measurement, compound 4: 1.8 percentage points above, and the stated range covers the measured number.
By their numbers in this assay, from the lowest: compounds 3, 4, 1 and 2 (each within the scatter of the next).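

In this assay the exchange for 2,4-dichlorophenyl on the aromatic nitrogen gives a number 2.7 percentage points higher from compound 3 to compound 4 (within the scatter) and a number 6.8 percentage points lower from compound 2 to compound 4 (within the scatter) and a number 4.8 percentage points lower from compound 1 to compound 4 (within the scatter) for the three aryl groups it replaces. Replacing the whole aryl group, and not only its single substituent, therefore leaves all four compounds within scatter, with no order among them. No measurement bears on why this position tolerates the exchange.

From the compounds shown here alone, whether an amine or a carboxylic acid on this aryl group would shift the read-out stays open. So does the effect of a longer chain in its place.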